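The source may hold more compounds than are shown below. What is called first, only, known or untested is meant among the compounds shown, and "the series" means these compounds.

Measured in a functional assay on HeLa cells (Homo sapiens) for cytotoxicity, read by sulforhodamine B assay; a lower number here means a stronger inhibitor, a higher number a weaker inhibitor:
- compound 1 `COc1cccc2cc(N(C)c3nc(C)nc4ccccc34)ccc12`: 1.7 nM
- compound 2 `COc1ccc2c(c1)CCCN2c1ncnc2ccccc12`: 13.1 nM

Compound 1 holds the lower of these two numbers, and its gap to compound 2 lies beyond the usual scatter. Compound 3 `COc1cccc2cc(N(C)c3nc(Cl)nc4ccccc34)ccc12` has not yet been measured in this assay. It differs from compound 1 in one place: chloro in place of methyl on an aromatic carbon, between two ring nitrogen atoms. Going by the values given here, no measured pair of compounds shows this change, so the data give no direct guide to its size. The expectation rests on compound 1 at 1.7 nM, whose remaining structure compound 3 keeps. A small move toward a higher number is expected, not clearly beyond the scatter. The estimated change is a 1.8-fold higher number from compound 1 to compound 3 (0.25 log units; within the scatter). Compound 3 is expected at 3 nM, with an estimated range of 1 nM to 10 nM.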

Compound 3, half-maximal inhibitory concentration: 1.6 nM
Compound 3: middle estimate off by 1.9-fold (0.27 log units), on the high side; the measured number falls inside the stated range.
By their numbers in this assay, from the lowest: compounds 3 and 1 (each within the scatter of the next); then compound 2.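

In this assay, chloro in place of methyl on the aromatic carbon between two ring nitrogen atoms gives a 1.1-fold lower number from compound 1 to compound 3 (0.03 log units; within the scatter), so the two compounds cannot be told apart. Going by these compounds alone, the earlier compounds offered no pair that changed at this position, and this single step is the first direct reading of it. On the core of compound 1, the position carries either methyl or chloro with no difference that the assay can resolve. No available evidence accounts for this equivalence.

On these data alone, whether an amine, a methoxy group or a longer chain at this position would give a number close to those of compound 1 and compound 3 remains open. So does whether chloro and methyl would also match on a different core, since this one pair rests on the core of compound 1 alone.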